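Working notes on a three-compound series

A few compounds are considered here, and "the series" means these few. Any claim that something is new, unique, unknown or untested is made for them only; others in the source may bear on it.

Of the compounds shown here, two have been measured. Compound 1 `CC1(C)S[C@@H]2/C(=C\C(=O)c3ccco3)C(=O)N2[C@H]1C(=O)OC(c1ccccc1)c1ccccc1` carries a (furan-2-yl)carbonyl on the double-bonded chain carbon of the shared core; in a functional assay on OE19 cells (Homo sapiens) for cytotoxicity, read by MTT assay, with a stated time of 48 h (on this read-out lower numbers stand for stronger inhibition and higher numbers for weaker inhibition), compound 1 gives 54300 nM. Compound 2 `CC1(C)[C@H](C(=O)OC(c2ccccc2)c2ccccc2)N2C(=O)/C(=C/C(=O)c3ccccc3)[C@H]2S1(=O)=O` differs from compound 1 in more than one place; in this assay compound 2 gives 53100 nM. These two numbers lie within the scatter of each other, so compound 1 does not stand apart from compound 2 on the numbers shown, and the whole measured set sits at a single level. Among the compounds with values here, no step between measured compounds that differ in one place exists, so the size of any single change is unknown.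

Compound 3 `CC1(C)S[C@@H]2/C(=C\C(=O)c3ccc([N+](=O)[O-])cc3)C(=O)N2[C@H]1C(=O)OC(c1ccccc1)c1ccccc1` is the unmeasured analogue and differs from compound 1 in one place: 4-nitrophenyl in place of furan-2-yl on a carbonyl carbon. Within the data shown here, with no measured step to lean on, the expected change in this assay is a 1.2-fold lower number from compound 1 to compound 3 (0.08 log units; within the scatter), that is, none beyond the scatter. Compound 3 is accordingly estimated at 45000 nM, with a range from 15000 nM to 130000 nM.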

Compound 3, half-maximal inhibitory concentration: 44100 nM
Compound 3: middle estimate off by 1.0-fold (0.01 log units), on the high side; the range from low to high includes it.
By their numbers in this assay, from the lowest: compounds 3, 2 and 1 (each within the scatter of the next).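

In this assay, within the data shown here, the change to 4-nitrophenyl in place of furan-2-yl on a carbonyl carbon gives a 1.2-fold lower number from compound 1 to compound 3 (0.09 log units; within the scatter), and this is the first step between compounds that differ in one place. At this position, one five-membered aromatic ring with 1 hetero atom and 5 heavy atoms can therefore give way to one six-membered aromatic ring of carbon only, in a group of 9 heavy atoms, without the number leaving the scatter. No measurement shown here accounts for this result.

The compounds shown leave open whether any group on this carbonyl carbon can move the number beyond the scatter, since a basic amine, a carboxylic acid or a longer alkyl chain in this place does not appear among them. Among these compounds, they also leave open what the other differences carried by compound 2 contribute on their own, as compound 2 differs from compound 1 in more than one place and no single step to it can be read.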